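The compounds below may be only part of what the source reports. "The series", "measured", "known", "first", "only" and "open" are said of these compounds alone.

Of the compounds shown here, three with the same core have been measured in a physicochemical assay for lipophilicity; on this read-out lower numbers stand for lower lipophilicity and higher numbers for higher lipophilicity: compound 1 `CC(C)(C)C#Cc1cc(N(C(=O)[C@H]2CC[C@H](C)CC2)[C@H]2CC[C@H](Oc3ccc4nccn4n3)CC2)c(C(=O)O)s1` gives 2.4, compound 2 `CC(C)(C)C#Cc1cc(N(C(=O)[C@H]2CC[C@H](C)CC2)[C@H]2CC[C@H](OC3COC3)CC2)c(C(=O)O)s1` gives 2.6, and compound 3 `CC(C)(C)C#Cc1cc(N(C(=O)[C@H]2CC[C@H](C)CC2)[C@H]2CC[C@H](OC3CCOCC3)CC2)c(C(=O)O)s1` gives 2.4. Compound 3 therefore stands level with compound 1 and within the usual scatter of compound 2.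

The next compound, compound 4 `CC(C)(C)C#Cc1cc(N(C(=O)[C@H]2CC[C@H](C)CC2)[C@H]2CC[C@H](OC3CCOC3)CC2)c(C(=O)O)s1`, differs from compound 3 in one group: oxolan-3-yl in place of oxan-4-yl on an oxygen on a saturated carbon. Put simply, oxolan-3-yl stands in place of oxan-4-yl on an oxygen on a saturated carbon.

The closest guide is the swap of oxetan-3-yl for oxan-4-yl, a number 0.20 log units lower from compound 2 to compound 3 (within the scatter). The two swaps away from the larger group of compound 1 were also small, a number 0.20 log units higher from compound 1 to compound 2 (within the scatter) and no change at the digits printed from compound 1 to compound 3 (within the scatter). None of these three steps stands out from the scatter, so no real shift is expected in this assay. The expected step is a number 0.10 log units higher from compound 3 to compound 4 (within the scatter), which is no more than scatter. The estimated value for compound 4 is 2.5, with an expected range of 2.2 to 2.8.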

Compound 4, distribution coefficient: 2.3
For compound 4 the middle estimate is 0.20 log units above the measured one; the range from low to high includes it.
By their numbers in this assay, from the lowest: compounds 4, 1, 3 and 2 (each within the scatter of the next).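

In this assay, oxolan-3-yl on an oxygen on a saturated carbon can be compared with three other groups: oxan-4-yl (a number 0.10 log units lower from compound 3 to compound 4 (within the scatter)), oxetan-3-yl (a number 0.30 log units lower from compound 2 to compound 4 (within the scatter)) and the larger group of compound 1 (a number 0.10 log units lower from compound 1 to compound 4 (within the scatter)). All three steps lie within the scatter, so the five-membered ring now joins the four-membered and six-membered rings, each with one oxygen, and the two-ring aromatic group of compound 1 as groups this read-out cannot tell apart at this place. No separate evidence bears on this result.

As far as these compounds go, whether a group of another kind on this oxygen, such as piperidin-4-yl, which carries an amine, or a longer chain ending in a carboxylic acid, would give a step beyond the scatter stays open.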